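Replacing the aryl amide of compound 3 with an acetamide

The source may report more compounds than this note shows. Statements on the series, on what has been measured and on what is new or still open speak of the compounds shown alone.

Compound 3 `CN(C)CCNc1cc2c(cn1)cc(NC(=O)c1ccc(Cl)cc1)c(=O)n2C` gives 3090 nM in a functional assay on MCF7 cells (Homo sapiens) for antiproliferative activity, read by MTT assay, with a stated time of 48 h (on this read-out higher numbers stand for weaker inhibition and lower numbers for stronger inhibition), the lowest of the three numbers recorded so far. Compound 1 `CN(C)CCNc1cc2c(cn1)cc(NC(=O)c1cc3ccccc3s1)c(=O)n2C` gives 12000 nM in this assay, and compound 2 `CN(C)CCNc1cc2c(cn1)cc(NC(=O)c1ccc(N)cc1)c(=O)n2C` gives 55800 nM in this assay. The steps among these three are a 3.9-fold lower number from compound 1 to compound 3 (0.59 log units; beyond the scatter), a 4.7-fold higher number from compound 1 to compound 2 (0.67 log units; beyond the scatter) and an 18-fold lower number from compound 2 to compound 3 (1.26 log units; beyond the scatter), all beyond the scatter.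

Compound 4 `CC(=O)Nc1cc2cnc(NCCN(C)C)cc2n(C)c1=O` has not yet been measured. It differs from compound 3 in one place: methyl in place of 4-chlorophenyl on a carbonyl carbon. Among the compounds with values here, none of the measured steps removes the aromatic ring from the carbonyl carbon altogether. The steps of a 3.9-fold lower number from compound 1 to compound 3 (0.59 log units; beyond the scatter) and a 4.7-fold higher number from compound 1 to compound 2 (0.67 log units; beyond the scatter) exchange one aromatic group for another at that carbon, and an 18-fold lower number from compound 2 to compound 3 (1.26 log units; beyond the scatter) changes only a substituent on that ring; together they show that this assay is sensitive to the group on the carbonyl carbon, with the numbers spreading over a wide range. Within the data shown here, a bare methyl there has no precedent among the measured compounds, so the expectation rests on that spread alone. Compound 4 is therefore expected to give 30000 nM in this assay, with a range from 8000 nM to 120000 nM, which would mean a step of a 9.7-fold higher number from compound 3 to compound 4 (0.99 log units; beyond the scatter).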

Compound 4, half-maximal inhibitory concentration: > 100000 nM
Compound 4: a limit, no number; the forecaster's own chance of this, stated with the estimate: 20%; at least 3.3-fold (0.52 log units) between middle value and limit.
By their numbers in this assay, from the lowest: compound 3; then compound 1; then compound 2. At a limit, above all of these: compound 4.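

Compound 4 alone gives a limit of the assay and not a number: the limit of > 100000 nM in this assay, at which 1 of the 4 values shown sits. The earlier compounds shown here only exchanged one aromatic group for another or changed a substituent on the ring, whereas here the ring leaves the carbonyl carbon altogether and methyl takes its place, and this costs far more than the swap between aromatic groups did: an at least 32-fold higher number from compound 3 to compound 4 (1.51 log units; beyond the scatter) and an at least 8.3-fold higher number from compound 1 to compound 4 (0.92 log units; beyond the scatter). The trend that an aromatic group on the carbonyl carbon gives lower numbers than methyl holds for compound 1 and compound 3 only, and compound 2 goes against it: an at least 1.7-fold higher number from compound 2 to compound 4 (0.25 log units; that floor lies within the scatter), so compound 4 cannot be separated from compound 2.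

From the compounds shown here alone, how far the true value of compound 4 lies past its limit stays open, and with it the full size of these steps. Also open, going by these compounds, is whether a plain phenyl, a cyclohexyl ring or a longer alkyl chain on the carbonyl carbon would hold the number near that of compound 3, which would tell whether the chloro substituent, the aromatic ring or simply a larger group carries the effect.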